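This account rests on a few compounds, and the source may have more. Where it says the series, first, only, none or still open, it means among the compounds named here.

Compound 1 `ClCc1ccc(Cn2cnc3c(Cl)ncnc32)cc1` is the reference point of this small set. In a functional assay on SN12C cells (Homo sapiens) for cytotoxicity, read by sulforhodamine B assay, with a stated time of 48 h (on this read-out higher numbers stand for weaker inhibition of growth and lower numbers for stronger inhibition of growth), compound 1 gives 2340 nM. Compound 2 `Nc1nc(Cl)c2ncn(Cc3ccc(CCl)cc3)c2n1` differs from it by one change, (amino in place of hydrogen on an aromatic carbon), and in this assay compound 2 gives 26900 nM; the step is an 11-fold higher number from compound 1 to compound 2 (1.06 log units; beyond the scatter). Compound 3 `ClCc1ccccc1Cn1cnc2c(Cl)ncnc21` has the same atoms as compound 1 joined differently; the difference between the two cores is not broken down here. In this assay compound 3 gives 8710 nM. Among the compounds with values here, compound 4 `Nc1nc(Cl)c2ncn(Cc3ccccc3CCl)c2n1` is not yet measured and carries the same change as the one from compound 1 to compound 2, (amino in place of hydrogen on an aromatic carbon), with the place described in the same words. Resting on the step of an 11-fold higher number from compound 1 to compound 2 (1.06 log units; beyond the scatter), the step is expected to be a 9.2-fold higher number from compound 3 to compound 4 (0.96 log units; beyond the scatter). In this assay compound 4 is therefore estimated at 80000 nM, expected between 25000 nM and 250000 nM.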

Compound 4, concentration for total growth inhibition: 5620 nM
Compound 4: the middle estimate sits 14-fold (1.15 log units) above what was measured; measured number below the stated range.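

The new step is a 1.5-fold lower number from compound 3 to compound 4 (0.19 log units; within the scatter), so on the core of compound 3 the amino in place of hydrogen on an aromatic carbon gives no difference that can be told from scatter. In this assay the same change therefore does not carry over from one core to the other: the same change on two cores in this assay, an 11-fold higher number (1.06 log units; beyond the scatter) from compound 1 to compound 2 and a 1.5-fold lower number (0.19 log units; within the scatter) from compound 3 to compound 4, 18-fold (1.25 log units) apart, beyond the scatter of two such steps. This shows that the step measured on one core cannot stand in for the step on the other, but two pairs do not show why the steps part, or what the change would do on any further core.

The compounds shown leave open whether a group other than amino at this place, such as methylamino or hydroxyl, would also give steps that part between the two cores. They also leave open what a bromomethyl or hydroxymethyl group in place of the chloromethyl group would do.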